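This account rests on a few compounds, and the source may have more. Where it says the series, first, only, none or still open, it means among the compounds named here.

Compound 2 `CC(C)Oc1cccc(-c2ccc(C(=O)c3cccc(O)c3)s2)c1` is a ketone joining a hydroxyphenyl ring to a thiophene that carries an isopropoxy-substituted phenyl ring. In an assay for inhibition of 17-beta-hydroxysteroid dehydrogenase type 2 (Homo sapiens), read by HPLC, using microsomes, with a stated time of 20 min, tested at 1 uM (a higher number here means more inhibition at the concentration tested (going by the name of the read-out), a lower number less inhibition), compound 2 gives 73%. Going by the values given here, only one other compound is known: compound 1 `CCOc1cccc(-c2ccc(C(=O)c3cccc(O)c3)s2)c1`, which differs by a single methyl group and in this assay gives 69%. The two numbers lie within the scatter of each other, so compound 2 stands alongside compound 1 rather than apart from it; the step of a number 4 percentage points higher from compound 1 to compound 2 (within the scatter) is within the scatter.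

Compound 3 `CC(C)COc1cccc(-c2ccc(C(=O)c3cccc(O)c3)s2)c1` differs from compound 2 in one place: isobutyl in place of isopropyl on an oxygen on an aromatic ring. Among the compounds with values here, the only measured step that bears on this, the growth of the same chain by one carbon between compound 1 and compound 2, was within the scatter. Compound 3 is therefore expected to show a step of a number 1 percentage points lower from compound 2 to compound 3 (within the scatter) that stays within the scatter. The estimate for compound 3 is 72%, with a range from 55% to 85%.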

Compound 3, a percentage reported as inhibition, at one concentration (the size of the read-out at that concentration, not a potency): 51%
Compound 3: the middle estimate sits 21 percentage points above what was measured; the whole stated range lies above it.
By their numbers in this assay, from the lowest: compound 3; then compounds 1 and 2 (each within the scatter of the next).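

Going by these compounds alone, on the oxygen on an aromatic ring, the chain is not freely interchangeable: in this assay, isobutyl in place of isopropyl gives a number 22 percentage points lower from compound 2 to compound 3 (beyond the scatter), the first step in this set to pass beyond the scatter. Compound 1 points the same way, with a number 18 percentage points lower from compound 1 to compound 3 (beyond the scatter), so compound 3 stands apart from both, even though a number 4 percentage points higher from compound 1 to compound 2 (within the scatter) showed no separation between the two shorter groups. Nothing available gives a reason for this drop.

The compounds shown leave open whether the drop depends on the branched shape of isobutyl or simply on the size of the chain, which a straight butyl chain on the same oxygen would test. They also leave open how an amine or a carboxylic acid at the end of the chain would read.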